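The source may report more compounds than this note shows. Statements on the series, on what has been measured and on what is new or still open speak of the compounds shown alone.

Of the compounds shown here, three built on the shared core have been measured in an assay for inhibition of beta-glucuronidase (Bos taurus), read by spectrophotometry, with a stated time of 30 min; on this read-out lower numbers stand for stronger inhibition and higher numbers for weaker inhibition. Compound 1 `Oc1ccc(C(c2c[nH]c3ccc(Br)cc23)c2c[nH]c3ccc(Br)cc23)c(O)c1` gives 1620 nM. Compound 2 `Fc1ccccc1C(c1c[nH]c2ccc(Br)cc12)c1c[nH]c2ccc(Br)cc12` gives 18400 nM. Compound 3 `Clc1cccc(C(c2c[nH]c3ccc(Br)cc23)c2c[nH]c3ccc(Br)cc23)c1` gives 22300 nM, the highest of the three numbers; its nearest neighbour is compound 2, with a 1.2-fold higher number from compound 2 to compound 3 (0.08 log units; within the scatter), and its furthest is compound 1, with a 14-fold higher number from compound 1 to compound 3 (1.14 log units; beyond the scatter). Compound 4 `Cc1ccccc1C(c1c[nH]c2ccc(Br)cc12)c1c[nH]c2ccc(Br)cc12` has not yet been measured; it differs from compound 3 by 2-methylphenyl in place of 3-chlorophenyl on a saturated chain carbon bound to two aromatic carbons. All three measured steps change the group on that chain carbon and so bear on this exchange: an 11-fold higher number from compound 1 to compound 2 (1.06 log units; beyond the scatter), a 14-fold higher number from compound 1 to compound 3 (1.14 log units; beyond the scatter) and a 1.2-fold higher number from compound 2 to compound 3 (0.08 log units; within the scatter). The two large steps both replace the 2,4-dihydroxyphenyl, a group that neither compound 3 nor compound 4 carries, whereas the swap of 2-fluorophenyl for 3-chlorophenyl stayed within the scatter. The expected step is a 1.1-fold lower number from compound 3 to compound 4 (0.05 log units; within the scatter), within the scatter, because the like exchange a 1.2-fold higher number from compound 2 to compound 3 (0.08 log units; within the scatter) stayed there. In this assay compound 4 is estimated at 20000 nM, with a range from 8000 nM to 50000 nM.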

Compound 4, half-maximal inhibitory concentration: 20900 nM
Beside the measured number, compound 4's estimate is 1.0-fold (0.02 log units) below it; the measured number falls inside the stated range.
By their numbers in this assay, from the lowest: compound 1; then compounds 2, 4 and 3 (each within the scatter of the next).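

In this assay, exchanging the 3-chlorophenyl for 2-methylphenyl on a saturated chain carbon bound to two aromatic carbons gave a 1.1-fold lower number from compound 3 to compound 4 (0.03 log units; within the scatter), and methyl in place of fluoro on an aromatic carbon gave a 1.1-fold higher number from compound 2 to compound 4 (0.06 log units; within the scatter), so a group of carbon only reads the same here as the two halogen-bearing ones. The 2,4-dihydroxyphenyl stays apart with a 13-fold higher number from compound 1 to compound 4 (1.11 log units; beyond the scatter), and compounds 2, 3 and 4 now form a group of three, with different substituents, that all sit well away from compound 1. Nothing given here explains why these three read alike or why compound 1 differs.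

Going by these compounds alone, compound 1 is the only compound carrying hydroxyl groups, so the set does not show whether both are needed or whether one alone would do. It also leaves open how a methoxy, an amine or a carboxylic acid on this phenyl ring would read.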